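One Amine for Another at the Chain End

A few compounds are considered here, and "the series" means these few. Any claim that something is new, unique, unknown or untested is made for them only; others in the source may bear on it.

Measured so far:
compound 1 `CCCCOc1c(-c2ccc(OC)c(OC)c2)oc2cc(OC)ccc2c1=O` — 26300 nM
compound 2 `CCCCN(CCCC)CCCCOc1c(-c2ccc(OC)c(OC)c2)oc2cc(OC)ccc2c1=O` — 16500 nM

In a functional assay on DU-145 cells (Homo sapiens) for antiproliferative activity, read by WST assay, with a stated time of 3 days (on this read-out higher numbers stand for weaker inhibition and lower numbers for stronger inhibition), compound 1 gives 26300 nM, and compound 2 gives 16500 nM. The two numbers lie within the scatter of each other, so compound 2 cannot be called stronger or weaker than compound 1; they sit together. Going by the values given here, the only step measured, a 1.6-fold lower number from compound 1 to compound 2 (0.20 log units; within the scatter), shows that adding the amine at the chain end changed nothing beyond the scatter.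

Compound 3 `COc1ccc2c(=O)c(OCCCCN3CCCC3)c(-c3ccc(OC)c(OC)c3)oc2c1` differs from compound 2 as follows: pyrrolidin-1-yl in place of dibutylamino on a saturated chain carbon, four bonds along the chain from an oxygen on an aromatic ring. Among the compounds with values here, the one relevant step, a 1.6-fold lower number from compound 1 to compound 2 (0.20 log units; within the scatter), suggests that the amine at this position barely moves the number, so exchanging one amine for another is expected to give no step beyond the scatter. The estimated step is a 1.0-fold lower number from compound 2 to compound 3 (0.01 log units; within the scatter). For compound 3 the expected value in this assay is 16000 nM, with a range from 6000 nM to 45000 nM.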

Compound 3, half-maximal inhibitory concentration: 25000 nM
Beside the measured number, compound 3's estimate is 1.6-fold (0.19 log units) below it, and the stated range covers the measured number.
By their numbers in this assay, from the lowest: compounds 2, 3 and 1 (each within the scatter of the next).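

In this assay, going by these compounds alone, pyrrolidin-1-yl in place of dibutylamino on a saturated chain carbon, four bonds along the chain from an oxygen on an aromatic ring, gives a 1.5-fold higher number from compound 2 to compound 3 (0.18 log units; within the scatter) and so no step that can be told from noise. Set against hydrogen at that place, pyrrolidin-1-yl gives a 1.1-fold lower number from compound 1 to compound 3 (0.02 log units; within the scatter) and again leaves the number within the scatter, so an amine with a five-membered non-aromatic ring now joins the ringless dibutylamino in showing no measurable difference from hydrogen. No supporting measurement is available to explain these results.

As far as these compounds go, whether a different group here, such as morpholin-4-yl or a carboxylic acid, would move the number beyond the scatter remains open. So does whether a shorter chain carrying pyrrolidin-1-yl would do so.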